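Resolving the ring stereocentre of compound 3

This account rests on a few compounds, and the source may have more. Where it says the series, first, only, none or still open, it means among the compounds named here.

Measured compounds:
compound 1 `CC1CC/C(=N\Nc2ccc(O)cc2)c2ncc(C(=O)O)c(=O)n21`, 1.7 umol/kg
compound 2 `COc1ccc(N/N=C2\CCC(C)n3c2ncc(C(=O)O)c3=O)cc1`, 0.8 umol/kg
compound 3 `CCOc1ccc(N/N=C2\CCC(C)n3c2ncc(C(=O)O)c3=O)cc1`, 1.6 umol/kg

In a functional assay on the whole organism for inhibition, with Rattus norvegicus as the target (a lower number here means that less compound is needed, a higher number that more compound is needed for the effect), compound 3 gives 1.6 umol/kg, the second highest of the three numbers. Compound 1 is nearest to it, and the two values lie within the scatter of each other, as the step of a 1.1-fold lower number from compound 1 to compound 3 (0.03 log units; within the scatter) shows. Compound 2 gives 0.8 umol/kg, the lowest number; the step of a 2.0-fold higher number from compound 2 to compound 3 (0.30 log units; within the scatter) also stays within the scatter, while a 2.1-fold lower number from compound 1 to compound 2 (0.33 log units; beyond the scatter) just passes beyond it.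

Compound 4 `CCOc1ccc(N/N=C2\CC[C@H](C)n3c2ncc(C(=O)O)c3=O)cc1` differs from compound 3 in one respect: the two compounds have the same atoms and bonds; at least one stereo element is drawn with a configuration in one of them and without one in the other: 1 of 2 stereo elements differ; a stereocentre at a saturated ring carbon is drawn without a configuration in compound 3 and S in compound 4. None of the three measured steps touches the stereocentre at the saturated ring carbon; all of them concern the group on the oxygen of the aromatic ring. Among the measured compounds shown here, there is thus no measured step that bears on this change, and the variations seen so far are small. In this assay compound 4 is expected to come out close to compound 3, with the step of a 1.3-fold lower number from compound 3 to compound 4 (0.12 log units; within the scatter) kept within the usual scatter, although a single drawn configuration can move the number in either direction. The estimate for compound 4 is 1.2 umol/kg, within a range from 0.5 umol/kg to 3.5 umol/kg.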

Compound 4, dose for 50% inhibition: 100 umol/kg
For compound 4 the middle estimate is 83-fold (1.92 log units) below the measured one; measured number above the stated range.
By their numbers in this assay, from the lowest: compounds 2, 3 and 1 (each within the scatter of the next, the first and the last beyond it); then compound 4.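

Drawing the stereocentre at a saturated ring carbon as S, with all atoms and bonds unchanged, gives the only large step seen so far in this assay (a 63-fold higher number from compound 3 to compound 4 (1.80 log units; beyond the scatter)). The earlier steps shown here all concerned the group on the oxygen of the aromatic ring; they stayed within the scatter or, in one case, just passed beyond it, and so gave no sign that the number could move this far at another place in the molecule. The S configuration drawn in compound 4 thus goes with a far higher dose than the drawing of compound 3, and the only structural difference to which this can be tied is the stereo element itself: the fact that one of compounds 3 and 4 is drawn with a defined configuration and the other without, at the place where they differ.

The compounds shown leave open how the R configuration at this carbon would read, and so which form, if either, accounts for the number of compound 3, whose drawing does not define it. They also leave open whether hydrogen or an ethyl in place of the methyl on this stereocentre would keep the number low or move it as sharply as the S configuration does.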